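Benzyl-substituted dichloro series: cytotoxicity at the limit

A few compounds are considered here, and "the series" means these few. Any claim that something is new, unique, unknown or untested is made for them only; others in the source may bear on it.

Compound 1 `Clc1ccc(Cn2c(Cl)nc3cc(Cl)c(Cl)cc32)cc1` and compound 2 `Cc1ccc(Cn2c(Cl)nc3cc(Cl)c(Cl)cc32)cc1` share one core and differ by methyl in place of chloro on an aromatic carbon. In a functional assay on CEM-SS cells (Homo sapiens) for cytotoxicity (on this read-out higher numbers stand for weaker inhibition and lower numbers for stronger inhibition), compound 1 reaches only the limit > 100000 nM. Compound 2 likewise gives only the limit > 100000 nM in this assay. The step that the two limits leave unreadable from compound 1 to compound 2 cannot be read, since (the limit of > 100000 nM in this assay, at which 3 of the 3 values shown sit). Compound 3 `Clc1cccc(Cn2c(Br)nc3cc(Cl)c(Cl)cc32)c1` carries a core whose difference from that of compound 1 is not broken down here; in this assay compound 3 also sits at the limit > 100000 nM. Compound 4 `Cc1cccc(Cn2c(Br)nc3cc(Cl)c(Cl)cc32)c1` is not yet measured and differs from compound 3 by methyl in place of chloro on an aromatic carbon, the same kind of change as that between compound 1 and compound 2, the place there being para to a large group and here meta to a large group. The step from compound 3 to compound 4 is expected to be a step that the limit leaves unreadable from compound 3 to compound 4, resting on the unreadable step that the two limits leave unreadable from compound 1 to compound 2 and on (the limit of > 100000 nM in this assay, at which 3 of the 3 values shown sit). Compound 4 is expected at 150000 nM in this assay, within a range from 100000 nM to 400000 nM.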

Compound 4, half-maximal inhibitory concentration: > 100000 nM
Compound 4 gave a limit, no number; the forecaster's own chance of this, stated with the estimate: 85%; the middle value lies beyond the limit too.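

No step can be read from compound 3 to compound 4, since both values are limits: the limit of > 100000 nM in this assay, at which 4 of the 4 values shown sit. The compounds shown leave open what methyl in place of chloro on an aromatic carbon does in this assay.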